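Benzyloxy added to the benzyl arm of an anilide

This account rests on a few compounds, and the source may have more. Where it says the series, first, only, none or still open, it means among the compounds named here.

Measured compounds:
- compound 1, `C#CCN(C)C(=O)c1cc2cc(NS(C)(=O)=O)ccc2n1Cc1ccc(OC)cc1`: 1500 nM
- compound 2, `CC(=O)N(Cc1ccccc1)c1cc(C)cc(C)c1`: 276 nM

Two compounds have numbers in an assay on membranes from HEK293 cells for displacement of a labelled ligand from Translocator protein (Homo sapiens), read by scintillation counting, with a stated time of 90 min; a lower number here means a stronger inhibitor, a higher number a weaker inhibitor. Compound 2 gives 276 nM, the lowest of the two numbers shown. Compound 1, a compound of a different shape built on its own core, gives 1500 nM in this assay, a number that lies beyond the usual scatter above that of compound 2. Within the data shown here, no pair of measured compounds differs in a single place, so no measured step is at hand to lean on.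

Compound 3, `CC(=O)N(Cc1ccc(OCc2ccccc2)cc1)c1cc(C)cc(C)c1`, is not yet measured. It differs from compound 2 in one place: benzyloxy in place of hydrogen on an aromatic carbon, on the benzyl arm that sits on the amide nitrogen, at the position described as para to a large group.

Among the measured compounds shown here, with no measured step of this kind to guide the guess, the expectation rests on compound 2 alone. The step from compound 2 to compound 3 is expected to be small, a 1.5-fold lower number from compound 2 to compound 3 (0.19 log units; within the scatter), likely within the scatter or at most a modest move toward a lower number. Compound 3 is therefore estimated at 180 nM in this assay, with a range from 40 nM to 900 nM.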

Compound 3, inhibition constant: 377 nM
The estimate for compound 3 lay 2.1-fold (0.32 log units) below the measured number, within the range that was stated.
By their numbers in this assay, from the lowest: compounds 2 and 3 (each within the scatter of the next); then compound 1.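

In this assay, putting benzyloxy in place of hydrogen on an aromatic carbon of the benzyl arm, para to a large group, gives a 1.4-fold higher number from compound 2 to compound 3 (0.14 log units; within the scatter), so the two compounds cannot be told apart by this measurement. Among these compounds, this is the first measured step at this position, and it shows that the position can carry a much larger group, one that brings its own six-membered aromatic ring, without the number moving outside the scatter. No supporting measurement bears on why the number holds when this group is added.

Going by these compounds, a single substituent says little about the position as a whole, so it remains open whether an amine, a carboxylic acid or a longer chain ending in a hydroxyl group would also leave the number within the scatter of compound 2. On these data alone, it also remains open whether benzyloxy would give a similar result elsewhere on the benzyl arm or on the other aromatic ring of compound 2.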